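A Side-Chain Exchange on Compound 3

The source may report more compounds than this note shows. Statements on the series, on what has been measured and on what is new or still open speak of the compounds shown alone.

Three compounds sharing one core have been examined so far. In a functional assay on HepG2 cells (Homo sapiens) for antiproliferative activity, read by MTT assay, with a stated time of 72 h (a lower number here means a stronger inhibitor, a higher number a weaker inhibitor), compound 1 (`O=C(N/N=C/c1ccccc1)Nc1ccc(Oc2ccnc3[nH]ccc23)cc1`) gives a half-maximal inhibitory concentration of 750 nM and carries no side chain on its aromatic nitrogen. For compound 2 (`O=C(N/N=C/c1ccc(O)cc1Br)Nc1ccc(Oc2ccnc3[nH]ccc23)cc1`) the record reads "not determined" (no result reported) and so offers no number. Compound 3 (`CCN(CC)CCn1cccc1/C=N/NC(=O)Nc1ccc(Oc2ccnc3[nH]ccc23)cc1`) stands at 5880 nM and holds the higher of the two available numbers, a gap from compound 1 that lies beyond the scatter.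

Compound 4 (`O=C(N/N=C/c1cccn1CCCN1CCCC1)Nc1ccc(Oc2ccnc3[nH]ccc23)cc1`) is still unmeasured and differs from compound 3 in one place ((pyrrolidin-1-yl)methyl in place of diethylamino on a saturated chain carbon, two bonds along the chain from an aromatic nitrogen). Cut one bond further out, 2-(diethylamino)ethyl gives way to 3-(pyrrolidin-1-yl)propyl.

For the measured compounds named here, no measured pair shows what such an exchange does. Going by the values given here, compound 3 (5880 nM) is the only measured compound with a comparable chain, so the expectation starts from it: no step beyond the scatter is expected in this assay and only a slight lean towards a lower number. The estimated move is a 1.4-fold lower number from compound 3 to compound 4 (0.15 log units; within the scatter) and is expected to stay within the scatter. Compound 4 is estimated at 4200 nM with 1500 nM to 11000 nM as the expected range.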

Compound 4, half-maximal inhibitory concentration: 1420 nM
The estimate for compound 4 lay 3.0-fold (0.47 log units) above the measured number; the whole stated range lies above it.
By their numbers in this assay, from the lowest: compounds 1 and 4 (each within the scatter of the next); then compound 3.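

In this assay, for the compounds shown here, replacing 2-(diethylamino)ethyl with 3-(pyrrolidin-1-yl)propyl gives a 4.1-fold lower number from compound 3 to compound 4 (0.62 log units; beyond the scatter) and provides the only measured step at this position, showing that the number responds to the group on a saturated chain carbon, two bonds along the chain from an aromatic nitrogen. The earlier values left compound 3 beyond the scatter from compound 1, whereas compound 4 lies within the scatter of compound 1, so a side chain on the aromatic nitrogen does not by itself set the number apart from that of the compound without one. No measured evidence on hand bears on what lies behind this step.

The exchange alters both the amine and the chain length, and the compounds shown do not separate the two: a 3-(diethylamino)propyl chain or a 2-(pyrrolidin-1-yl)ethyl chain on the shared core would be needed to do so. Going by these compounds, it also remains open whether the result extends to other chain ends, such as a piperidine or a morpholine, or to a chain longer than 3-(pyrrolidin-1-yl)propyl.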